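The source may report more compounds than this note shows. Statements on the series, on what has been measured and on what is new or still open speak of the compounds shown alone.

Compounds measured so far:
compound 1, `O=C1c2ccccc2CN1c1cnc(NCc2c(F)ccc3c2CCO3)n2cnnc12`, 2.7
compound 2, `Fc1ccc2c(c1CNc1ncc(Oc3ccccc3)c3nncn13)CCO2`, 3.5
compound 3, `Cn1nccc1-c1cnc(NCc2c(F)ccc3c2CCO3)c2cn[nH]c(=O)c12`, 2.6

In a physicochemical assay for lipophilicity, using the shake flask method, in phosphate buffer, measured as octanol-water partition, with a stated time of 30 min, at pH 7.4 (a higher number here means a more lipophilic compound, a lower number a more polar compound), compound 3 sits lowest of the three numbers; compound 1 stands 2.7, which lies within the scatter of compound 3, while compound 2 at 3.5 lies beyond it. Among the measured compounds shown here, the one step between measured compounds, a number 0.80 log units higher from compound 1 to compound 2 (beyond the scatter), concerns a change at a different position of the shared core and so gives only a rough sense of how much a swap of one group for another can move this assay.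

Compound 4, `CNC(=O)c1ncc(-c2cnc(NCc3c(F)ccc4c3CCO4)c3cn[nH]c(=O)c23)n1C`, differs from compound 3 in a single place: 1-methyl-2-(methylcarbamoyl)-1H-imidazol-5-yl in place of 1-methyl-1H-pyrazol-5-yl on an aromatic carbon. The group that enters is larger and carries one hydrogen-bond donor and three acceptors where the leaving group carried none and two. For the measured compounds named here, no measured pair shows this kind of change, so the expectation rests on the change itself. A downward step in this assay is expected, of about a number 0.40 log units lower from compound 3 to compound 4 (beyond the scatter), moderate in size.

For compound 4 the distribution coefficient is therefore estimated at 2.2, with a range from 1.6 to 2.8.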

Compound 4, distribution coefficient: 2.5
Beside the measured number, compound 4's estimate is 0.30 log units below it; the measured number falls inside the stated range.
By their numbers in this assay, from the lowest: compounds 4, 3 and 1 (each within the scatter of the next); then compound 2.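

In this assay, putting 1-methyl-2-(methylcarbamoyl)-1H-imidazol-5-yl in place of 1-methyl-1H-pyrazol-5-yl on this aromatic carbon gives a number 0.10 log units lower from compound 3 to compound 4 (within the scatter), so the read-out does not separate the two compounds. Among the compounds shown here, this is the first sign that, at this place on the shared core, a larger group carrying a hydrogen-bond donor, which the leaving group does not have, can enter with no step beyond the scatter, whereas the one earlier step, a number 0.80 log units higher from compound 1 to compound 2 (beyond the scatter), a swap of different groups, did go beyond it. Nothing measured here gives a reason for this result.

This single pair cannot show whether the same holds for other groups on this carbon: a carboxylic acid in place of the methylcarbamoyl group, or an amine such as dimethylamino, might give a different step. It also leaves open whether the same swap would give a similar step on the core of compound 1.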